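The source may hold more compounds than are shown below. What is called first, only, known or untested is meant among the compounds shown, and "the series" means these compounds.

Of the compounds shown here, three sharing one core have been tested in a functional assay on DU-145 cells (Homo sapiens) for cytotoxicity, read by MTT assay, with a stated time of 24 h; a lower number here means a stronger inhibitor, a higher number a weaker inhibitor: compound 1 (`CCCCCCCC/C=C\CCCCCCCCCCCC(=O)Nc1nnc(S[C@@H]2O[C@H](COC(C)=O)[C@H](OC(C)=O)[C@H](OC(C)=O)[C@H]2OC(C)=O)s1`) gives 28400 nM, compound 2 (`C=CCCCCCCCCC(=O)Nc1nnc(S[C@@H]2O[C@H](COC(C)=O)[C@H](OC(C)=O)[C@H](OC(C)=O)[C@H]2OC(C)=O)s1`) gives 22900 nM, and compound 3 (`CCCCCCCCCCCCCCCCCC(=O)Nc1nnc(S[C@@H]2O[C@H](COC(C)=O)[C@H](OC(C)=O)[C@H](OC(C)=O)[C@H]2OC(C)=O)s1`) gives 31200 nM. Compound 3 therefore stands within the scatter of both other compounds, with no clear separation from either. Compound 4 (`CCCCCCCCCCCCCCCC(=O)Nc1nnc(S[C@@H]2O[C@H](COC(C)=O)[C@H](OC(C)=O)[C@H](OC(C)=O)[C@H]2OC(C)=O)s1`) differs from compound 3 at one place in the chain: hydrogen in place of ethyl on a saturated chain carbon, ten or more bonds along the chain from a carbonyl carbon. Two measured chain changes bear on this one: a 1.1-fold higher number from compound 1 to compound 3 (0.04 log units; within the scatter), and a 1.4-fold higher number from compound 2 to compound 3 (0.13 log units; within the scatter). Neither step leaves the scatter, so no step beyond it is expected in this assay and no direction can be called. The estimate means a 1.1-fold lower number from compound 3 to compound 4 (0.05 log units; within the scatter), an expected step inside the scatter. For compound 4 the estimated value is 28000 nM, with an expected range from 19000 nM to 40000 nM.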

Compound 4, half-maximal inhibitory concentration: 30100 nM
For compound 4 the middle estimate is 1.1-fold (0.03 log units) below the measured one, and the stated range covers the measured number.
By their numbers in this assay, from the lowest: compounds 2, 1, 4 and 3 (each within the scatter of the next).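

In this assay, hydrogen in place of ethyl on a saturated chain carbon, ten or more bonds along the chain from a carbonyl carbon, gives a 1.0-fold lower number from compound 3 to compound 4 (0.02 log units; within the scatter), so this one-place change in the saturated chain does not separate the two compounds. The steps to the two compounds with a chain double bond, a 1.3-fold higher number from compound 2 to compound 4 (0.12 log units; within the scatter) and a 1.1-fold higher number from compound 1 to compound 4 (0.03 log units; within the scatter), also stay inside the scatter, so compound 4 stands apart from none of the three earlier compounds. No independent evidence is available to account for this result.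

The compounds shown leave open whether an amine, a hydroxyl or a carboxylic acid at this place on the chain would give a step beyond the scatter in this assay. The same question stands for a much shorter chain.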